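The source may hold more compounds than are shown below. What is called first, only, known or untested is meant among the compounds shown, and "the series" means these compounds.

Working notes on the series. In a functional assay on MDA-MB-231 cells (Homo sapiens) for cytotoxicity, read by MTT assay, with a stated time of 72 h (a lower number here means a stronger inhibitor, a higher number a weaker inhibitor), compound 3 (`COc1ccc(/C=C/C(=O)CC(C)=O)cc1OC`) gives 43100 nM. That number lies within the scatter of compound 2 (`COc1ccc(/C=C/c2cc(C)no2)cc1OC`), which gives 79900 nM. Compound 1 (`COc1ccc(/C=C/c2cc(C)n[nH]2)cc1`) stands clearly lower, at 10700 nM.

The next change leads to compound 4 (`COc1ccc(/C=C/c2cc(C)n[nH]2)cc1OC`): 3-methyl-1H-pyrazol-5-yl in place of (2-oxopropyl)carbonyl on a double-bonded chain carbon bound to a double-bonded chain carbon, (3-methyl-1H-pyrazol-5-yl in place of (2-oxopropyl)carbonyl on a double-bonded chain carbon bound to a double-bonded chain carbon).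

Among the measured compounds shown here, only one measured step bears directly on this place. Replacing 3-methyl-1,2-oxazol-5-yl with (2-oxopropyl)carbonyl gave a 1.9-fold lower number from compound 2 to compound 3 (0.27 log units; within the scatter), so that exchange at this place moved the number by no more than the scatter. The pyrazole itself has been measured only in compound 1, which gives 10700 nM, and the core of compound 1 differs from that of compound 4 in its methoxy substitution. For the measured compounds named here, no measured pair isolates that core difference, so compound 1 serves only as a loose guide.

A modest move towards a lower number is therefore expected in this assay, close to the edge of the scatter. The estimated change is a 2.2-fold lower number from compound 3 to compound 4 (0.33 log units; beyond the scatter). For compound 4 the estimated value is 20000 nM, with an expected range of 7000 nM to 55000 nM.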

Compound 4, half-maximal inhibitory concentration: 38800 nM
Compound 4: middle estimate off by 1.9-fold (0.29 log units), on the low side, and the stated range covers the measured number.
By their numbers in this assay, from the lowest: compound 1; then compounds 4, 3 and 2 (each within the scatter of the next, the first and the last beyond it).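

In this assay, the new step at this place is a 1.1-fold lower number from compound 3 to compound 4 (0.05 log units; within the scatter), so 3-methyl-1H-pyrazol-5-yl and (2-oxopropyl)carbonyl are not told apart here, even though only the former carries a five-membered aromatic ring and a hydrogen-bond donor. Between the two rings, the step is a 2.1-fold lower number from compound 2 to compound 4 (0.31 log units; beyond the scatter), which makes 3-methyl-1H-pyrazol-5-yl in place of 3-methyl-1,2-oxazol-5-yl the first exchange on this double-bonded chain carbon to pass the scatter, though only modestly. The pair of compound 1 and compound 4 now isolates the difference that earlier left compound 1 a loose guide: methoxy in place of hydrogen on an aromatic carbon gives a 3.6-fold higher number from compound 1 to compound 4 (0.56 log units; beyond the scatter).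

No measurement here explains any of these steps. Still open, on these data alone, is whether the methoxy step holds with 3-methyl-1,2-oxazol-5-yl or (2-oxopropyl)carbonyl on the chain, and whether an amine or a carboxylic acid on this double-bonded chain carbon would move the number beyond the scatter of compound 4.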